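The source may report more compounds than this note shows. Statements on the series, on what has been measured and on what is new or still open speak of the compounds shown alone.

Measured compounds:
compound 1 `CC(C)c1ccc(S2=NS(=O)(=O)c3cc([N+](=O)[O-])ccc32)cc1` with 360 nM
compound 2 `CC(C)(C)c1ccc(S2=NS(=O)(=O)c3cc([N+](=O)[O-])ccc32)cc1` with 300 nM

In an assay on isolated protein for inhibition of Polyunsaturated fatty acid 5-lipoxygenase (Homo sapiens), read by immunoassay, with a stated time of 15 min (a lower number here means a stronger inhibitor, a higher number a weaker inhibitor), compound 2 has the lower of the two numbers, but the step of a 1.2-fold lower number from compound 1 to compound 2 (0.08 log units; within the scatter) is within the scatter, so the two compounds cannot be told apart on these data. Compound 3 `O=[N+]([O-])c1ccc2c(c1)S(=O)(=O)N=S2c1ccc(C(F)(F)F)cc1` differs from compound 2 in one place: trifluoromethyl in place of tert-butyl on an aromatic carbon. Going by the values given here, the only measured step, from isopropyl to tert-butyl, swapped one saturated group for another, and it was small. Among the compounds with values here, no measured step covers a change from an alkyl group to a trifluoromethyl group at this position, so the direction of any shift cannot be read from the data, and a step of about the size seen so far, or none beyond the scatter, is the most that can be expected. Compound 3 is therefore estimated at 400 nM, with a range from 150 nM to 1200 nM, an expected step of a 1.3-fold higher number from compound 2 to compound 3 (0.12 log units; within the scatter).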

Compound 3, half-maximal inhibitory concentration: 3090 nM
Compound 3: middle estimate off by 7.7-fold (0.89 log units), on the low side; the whole stated range lies below it.
By their numbers in this assay, from the lowest: compounds 2 and 1 (each within the scatter of the next); then compound 3.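

Replacing an alkyl group with trifluoromethyl on the aromatic ring has a large effect in this assay: there is a 10-fold higher number from compound 2 to compound 3 (1.01 log units; beyond the scatter), and an 8.6-fold higher number from compound 1 to compound 3 (0.93 log units; beyond the scatter). This shows that the position is not indifferent to what sits on it: isopropyl and tert-butyl could not be told apart, yet trifluoromethyl, with the same count of heavy atoms as tert-butyl, gives a clearly weaker inhibitor. Nothing measured here bears on why the number rises.

Going by these compounds alone, with only three groups compared on one shared core, it remains open whether this loss is specific to trifluoromethyl or extends to other non-alkyl groups. A chlorine atom, a methoxy group or an amine at the same place, or a ring carrying no group there, could help to separate these possibilities.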